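From Isobutyl to Cyclohexyl in a Weak Inhibitor

The compounds below may be only part of what the source reports. "The series", "measured", "known", "first", "only" and "open" are said of these compounds alone.

In a functional assay on brain (Rattus norvegicus, strain Wistar) for inhibition (a lower number here means a stronger inhibitor, a higher number a weaker inhibitor), compound 1 `CCCCc1ccc(-c2c(C)[nH]c(=O)n2-c2ccccc2)cc1` gives 16600 nM. Compound 2 `Cc1[nH]c(=O)n(C)c1-c1ccc(CC(C)C)cc1` gives 7800 nM, the lower of the two numbers, and this gap lies beyond the usual scatter. Compound 3 `Cc1[nH]c(=O)n(C)c1-c1ccc(C2CCCCC2)cc1` has not yet been measured. It carries cyclohexyl in place of isobutyl on an aromatic carbon. Within the data shown here, no measured pair of compounds isolates this kind of change, so only a small move toward stronger inhibition in this assay is expected, an estimated 1.6-fold lower number from compound 2 to compound 3 (0.19 log units; within the scatter). Compound 3 is estimated at 5000 nM, with an expected range from 1500 nM to 16000 nM.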

Compound 3, half-maximal inhibitory concentration: 10000 nM
The estimate for compound 3 lay 2.0-fold (0.30 log units) below the measured number, within the range that was stated.
By their numbers in this assay, from the lowest: compounds 2, 3 and 1 (each within the scatter of the next, the first and the last beyond it).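

In this assay, replacing isobutyl with cyclohexyl on this aromatic carbon gives a 1.3-fold higher number from compound 2 to compound 3 (0.11 log units; within the scatter). This position therefore takes a six-membered non-aromatic ring in place of an open branched chain, with no difference that can be told from the scatter. The data offer no measurement that bears on this result. Both groups contain carbon only, so the compounds shown leave open how an amine or a carboxylic acid at this position would read. From the compounds shown here alone, a methyl group or a longer chain here also remains open.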